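This account rests on a few compounds, and the source may have more. Where it says the series, first, only, none or still open, it means among the compounds named here.

Working notes on a small amide series in an ADME assay on HEK293 cells (Homo sapiens) for cytotoxicity, read by MTT assay, with a stated time of 48 h; a higher number here means a weaker inhibitor, a lower number a stronger inhibitor.

Compound 1 `Cc1cc(NC(=O)c2ccc(Cl)cc2)ccc1NS(C)(=O)=O` carries a methanesulfonamido group on the shared core and in this assay gives 50300 nM. Compound 3 `CCS(=O)(=O)Nc1ccc(NC(=O)c2ccc(Cl)cc2)cc1C` differs from compound 1 only by methyl in place of hydrogen on a saturated chain carbon bound to a sulfonyl sulfur; in this assay compound 3 gives 125000 nM. The step of a 2.5-fold higher number from compound 1 to compound 3 (0.40 log units; beyond the scatter) is modest but clears the scatter. Compound 2 `Cc1cc(NC(=O)c2cccc(C(F)(F)F)c2)ccc1NS(C)(=O)=O` carries a trifluoromethyl-substituted benzamide instead of the chlorobenzamide of compound 1; how the two cores differ is not broken down here. In this assay compound 2 gives 194000 nM, the highest of the three numbers, within the scatter of compound 3 and beyond it relative to compound 1.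

Compound 4 `CCS(=O)(=O)Nc1ccc(NC(=O)c2cccc(C(F)(F)F)c2)cc1C` has not yet been measured. It differs from compound 2 by methyl in place of hydrogen on a saturated chain carbon bound to a sulfonyl sulfur, the same change that was made from compound 1 to compound 3, at the same place. Within the data shown here, only one measured pair shows this change, so the expectation rests on that single step a 2.5-fold higher number from compound 1 to compound 3 (0.40 log units; beyond the scatter). An upward step of a similar size, a 1.8-fold higher number from compound 2 to compound 4 (0.26 log units; within the scatter), is expected from compound 2 to compound 4, allowing for the fact that compound 2 already stands at a high number where the assay may only return a limit. For compound 4 the estimated value in this assay is 350000 nM, with a range from 150000 nM to 800000 nM.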

Compound 4, half-maximal inhibitory concentration: 210000 nM
Compound 4: the middle estimate sits 1.7-fold (0.22 log units) above what was measured; the range from low to high includes it.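

In this assay, the change from methanesulfonamido to (ethylsulfonyl)amino on the core of compound 2 gives a 1.1-fold higher number from compound 2 to compound 4 (0.03 log units; within the scatter), whereas the same change on the core of compound 1 gave a 2.5-fold higher number from compound 1 to compound 3 (0.40 log units; beyond the scatter). Among these compounds, only the step on the core of compound 1 clears the scatter, but the two steps cannot be told apart: the same change on two cores in this assay, a 2.5-fold higher number (0.40 log units; beyond the scatter) from compound 1 to compound 3 and a 1.1-fold higher number (0.03 log units; within the scatter) from compound 2 to compound 4, 2.3-fold (0.36 log units) apart, within the scatter of two such steps. Among the compounds shown here, the two cores therefore give no evidence that the result of this change depends on the core, but with only two pairs they also do not show that a step of one fixed size carries from one core to another, and the step on the core of compound 2 taken alone shows no effect of the added methyl.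

The compounds shown leave open how a longer chain such as propyl on the sulfonyl group, or a sulfonamide chain ending in an amine or a carboxylic acid, would read in this assay. They also leave open whether the change from methyl to ethyl gives a step of similar size on benzamides that carry a group other than chloro or trifluoromethyl, such as a nitrile or a methoxy group.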